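Methyl to Ethyl on the Ring Amine, Seen Twice

This account rests on a few compounds, and the source may have more. Where it says the series, first, only, none or still open, it means among the compounds named here.

Compound 1, `CN1CCN(CCCCC(=O)N2CCN(CC(=O)Nc3cccc(Cl)c3)CC2)CC1`, sits at the assay limit of < 1% in an assay on cells (Oocyte) for inhibition of Voltage-dependent T-type calcium channel subunit alpha-1H (Homo sapiens), tested at 100 uM; a lower number here means less inhibition, a higher number more inhibition at the concentration tested (going by the name of the read-out).
Compound 2, `CCN1CCN(CCCCC(=O)N2CCN(CC(=O)Nc3cccc(Cl)c3)CC2)CC1`, gives 71.6% in this assay.
Compound 3, `CN1CCN(CCCCC(=O)N2CCN(CC(=O)Nc3cccc(C(F)(F)F)c3)CC2)CC1`, sits at the assay limit of < 1% in this assay.

The change methyl in place of hydrogen on a saturated chain carbon bound to an amine nitrogen in a ring brought a number at least 70.6 percentage points higher from compound 1 to compound 2 (beyond the scatter). The cores of compound 1 and compound 3 differ by trifluoromethyl in place of chloro on an aromatic carbon, and that step is a step that the two limits leave unreadable from compound 1 to compound 3 because of the limit of < 1% in this assay, at which 2 of the 3 values shown sit.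

Compound 4, `CCN1CCN(CCCCC(=O)N2CCN(CC(=O)Nc3cccc(C(F)(F)F)c3)CC2)CC1`, has not been measured. It stands to compound 3 as compound 2 stands to compound 1: methyl in place of hydrogen on a saturated chain carbon bound to an amine nitrogen in a ring, the same change in the same place. In this assay, going by the values given here, compound 4 is expected to show a number at least 44 percentage points higher from compound 3 to compound 4 (beyond the scatter), an expectation resting on the step of a number at least 70.6 percentage points higher from compound 1 to compound 2 (beyond the scatter), though with a wider spread since only one such pair has been measured and the two cores differ. The estimate for compound 4 is 45%, expected to fall between 5% and 80%.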

Compound 4, a percentage reported as inhibition, at one concentration (the size of the read-out at that concentration, not a potency): 23.6%
For compound 4 the middle estimate is 21.4 percentage points above the measured one, and the stated range covers the measured number.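

On the core of compound 3, methyl to ethyl on the ring amine again brought a rise in this assay, a number at least 22.6 percentage points higher from compound 3 to compound 4 (beyond the scatter), so the direction of the change held on both cores: the same change on two cores in this assay, a number at least 70.6 percentage points higher (beyond the scatter) from compound 1 to compound 2 and a number at least 22.6 percentage points higher (beyond the scatter) from compound 3 to compound 4; the limit leaves it open whether they differ. On these data alone, this does not show that the size of the step carries over, as both steps start from a limit and their true sizes remain unknown: the limit of < 1% in this assay, at which 2 of the 4 values shown sit. The core still counts once the ethyl group is in place, as trifluoromethyl in place of chloro on an aromatic carbon gave a number 48 percentage points lower from compound 2 to compound 4 (beyond the scatter), so the gain seen on one core cannot be taken as a fixed amount for another.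

The compounds shown leave open whether a longer chain on the ring amine, such as propyl or butyl, would raise the number further or lower it. They also leave open how other groups in place of chloro and trifluoromethyl on the aromatic carbon, such as fluoro or methoxy, would behave with ethyl on the ring amine.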